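The source may report more compounds than this note shows. Statements on the series, on what has been measured and on what is new or still open speak of the compounds shown alone.

Compound 1 `CCc1ccc(NC(=O)C2CCN(C/C=C/c3ccccc3)CC2)cc1` is tested in a functional assay on MGC-803 cells (Homo sapiens) for inhibition, read by MTT assay, with a stated time of 72 h (a higher number here means a weaker inhibitor, a lower number a stronger inhibitor), where compound 1 gives 11600 nM. Among the three compounds measured, compound 1 stands second highest; its nearest neighbour is compound 3 `O=C(Nc1cccc(F)c1)C1CCN(C/C=C/c2ccccc2)CC1`, which gives 23300 nM, and its furthest is compound 2 `CCCc1ccc(NC(=O)C2CCN(C/C=C/c3ccccc3)CC2)cc1`, which gives 5210 nM. The step from compound 1 to compound 2 is a 2.2-fold lower number from compound 1 to compound 2 (0.35 log units; beyond the scatter), and the step from compound 1 to compound 3 is a 2.0-fold higher number from compound 1 to compound 3 (0.30 log units; within the scatter).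

The unmeasured compound 4 `O=C(Nc1ccccn1)C1CCN(C/C=C/c2ccccc2)CC1` differs from compound 1 in one place: pyridin-2-yl in place of 4-ethylphenyl on an amide-type nitrogen. Among the compounds with values here, the steps that bear on this change are those in which the group on the amide-type nitrogen is swapped. The step from compound 1 to compound 3 was a 2.0-fold higher number from compound 1 to compound 3 (0.30 log units; within the scatter), and the step from compound 2 to compound 3 was a 4.5-fold higher number from compound 2 to compound 3 (0.65 log units; beyond the scatter). Both steps replace an alkylphenyl group with a smaller aromatic ring, and both gave a higher number. The move to pyridin-2-yl is a similar kind of swap, so the expectation for compound 4 is a modest increase in this assay, with a step estimated as a 1.7-fold higher number from compound 1 to compound 4 (0.24 log units; within the scatter). The estimated value for compound 4 is therefore 20000 nM, expected to lie between 9000 nM and 45000 nM.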

Compound 4, half-maximal inhibitory concentration: 45200 nM
Compound 4: middle estimate off by 2.3-fold (0.35 log units), on the low side; the measured number lies above the stated range.
By their numbers in this assay, from the lowest: compound 2; then compounds 1, 3 and 4 (each within the scatter of the next, the first and the last beyond it).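

In this assay, within the data shown here, pyridin-2-yl is the first ring on the amide-type nitrogen to carry a hetero atom, and the swap from 4-ethylphenyl gives a 3.9-fold higher number from compound 1 to compound 4 (0.59 log units; beyond the scatter), a step beyond the scatter, unlike the swap from 4-ethylphenyl to 3-fluorophenyl. Measured against 4-propylphenyl, the same change gives an 8.7-fold higher number from compound 2 to compound 4 (0.94 log units; beyond the scatter), the largest step among these compounds, while the comparison with 3-fluorophenyl gives a 1.9-fold higher number from compound 3 to compound 4 (0.29 log units; within the scatter), so these two rings cannot be told apart in this assay. Nothing measured here explains these differences.

The change removes the ethyl chain and brings in a ring nitrogen at the same time, so the contribution of each stays unresolved; a plain phenyl group, or a pyridine ring carrying an ethyl group, would separate the two. Also open, going by these compounds, is whether a longer chain such as butyl, or an amine or carboxylic acid on the ring, would move the number up or down from the values seen with the ethyl and propyl groups.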